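The compounds below may be only part of what the source reports. "The series", "measured", "known", "first", "only" and "open" are said of these compounds alone.

Measured compounds:
Compound 1 `CCOC(=O)c1cccc(NC(=O)[C@@H]2C[C@H](SC3=C(C(=O)O)N4C(=O)[C@H]([C@@H](C)O)[C@H]4[C@H]3C)CN2)c1`: "not determined" (no result reported)
Compound 2 `CCOC(=O)C1=C(S[C@@H]2CN[C@H](C(=O)Nc3cccc(C(=O)OCC)c3)C2)[C@H](C)[C@@H]2[C@@H]([C@@H](C)O)C(=O)N12`: 0%

In an ADME assay on a cell-free system (plasma, Rattus norvegicus) for metabolic stability, read by LC-MS, with a stated time of 60 min, at 37 degrees C, tested at 50 uM (a lower number here means that less of the compound is left, a higher number that more of the compound is left), compound 2 gives 0%, which means none of it was found at the end of the run. Among the compounds with values here, for compound 1 no number was reported in this assay, so compound 2 stands alone as the only compound with a measured value, and there is no measured step to compare against.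

Compound 3 `CCOC(=O)C1=C(S[C@H]2C[C@@H](C(=O)Nc3cccc(C(=O)OCC)c3)N(Cc3oc(=O)oc3C)C2)[C@H](C)[C@@H]2[C@@H]([C@@H](C)O)C(=O)N12` differs from compound 2 by a group of 8 heavy atoms (5 carbon, 3 oxygen; one five-membered aromatic ring with 2 hetero atoms) in place of a hydrogen atom, on an amine nitrogen in a ring. Within the data shown here, no pair of measured compounds shows what such a change does in this assay, so the expectation rests on the one value at hand. Since compound 2 sits at the floor of the scale, the step can only be flat or upward. Compound 3 is expected to give 10%, with a likely range from 0% to 40%, which amounts to an estimated step of a number 10 percentage points higher from compound 2 to compound 3 (within the scatter), most of it within the usual scatter.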

Compound 3, percent of the compound remaining: 0%
The estimate for compound 3 lay 10 percentage points above the measured number; the measured number falls inside the stated range.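

In this assay there is no change at the digits printed from compound 2 to compound 3 (within the scatter), so a group of 8 heavy atoms on the amine nitrogen in the ring, in place of a hydrogen atom, leaves the read-out where it was. Both compounds sit at the very bottom of the scale, and at that floor the read-out cannot tell whether either one disappears early or late in the run. Nothing at hand explains this result.

On these data alone, it remains open whether a smaller group on this same nitrogen, such as a methyl or an acetyl group, would leave any compound at the end of the run. As far as these compounds go, it is also open whether replacing either ethyl ester with a different group, such as a primary amide, would lift a compound off this floor.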